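A few compounds are considered here, and "the series" means these few. Any claim that something is new, unique, unknown or untested is made for them only; others in the source may bear on it.

Measured compounds:
compound 1, `Cc1cc(NC(=O)Nc2ncccc2C)c2ccccc2n1`: > 25000 nM
compound 2, `COC(=O)c1ccc(NC(=O)Nc2cc(C)nc3ccccc23)cc1`: 20000 nM
compound 3, `COc1cccc(NC(=O)Nc2cc(C)nc3ccccc23)c1`: > 25000 nM

In an ADME assay on HepG2 cells (Homo sapiens) for cytotoxicity, with a stated time of 72 h (on this read-out lower numbers stand for an effect already at smaller amounts and higher numbers for an effect only at larger amounts of compound), compound 1 gives > 25000 nM, which is a limit of the assay rather than a number. Compound 3 likewise gives > 25000 nM, also a limit. Compound 2 alone gives a number, 20000 nM. Compound 1 thus stands at the limit of > 25000 nM in this assay, at which 2 of the 3 values shown sit, and nothing separates it from its neighbours beyond the scatter.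

Compound 4, `Cc1cc(NC(=O)Nc2ccccc2N)c2ccccc2n1`, differs from compound 1 by 2-aminophenyl in place of 3-methylpyridin-2-yl on an amide-type nitrogen. For the measured compounds named here, no pair of measured compounds shows a step that could guide this change, so the step of a number no higher from compound 1 to compound 4 (the limit leaves the size open) is expected to be none beyond the scatter. Compound 4 is therefore expected to give 25000 nM, between 10000 nM and 60000 nM, most likely reported again as a limit.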

Compound 4, half-maximal effective concentration: > 25000 nM
Compound 4 ended at the assay's limit; the forecaster's own chance of this, stated with the estimate: 70%; the middle value lies on the limit itself.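

For the compounds shown here, compound 4 gives > 25000 nM, which is a limit, as is the result for compound 1, so no step between these two compounds can be read. Going by these compounds, whether 2-aminophenyl and 3-methylpyridin-2-yl differ at all in this assay remains open.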